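The compounds below may be only part of what the source reports. "The series", "measured", "known", "first", "only" and "open" are said of these compounds alone.

Measured so far:
- compound 1, `Cc1ccc2c(c1)oc(=O)n2Cc1cn(-c2ccc(F)cc2)nn1`, gives 80.6% in a functional assay on the whole organism (strain albino Wistar) for inhibition, with Rattus norvegicus as the target, read by paw edema, with stated times of 1 h and 5 h, at a dose of 0.05 mmol/kg by the oral route; on this read-out higher numbers stand for more inhibition at the one dose given (going by the name of the read-out) and lower numbers for less inhibition.
- compound 2, `O=c1oc2ccc(Cl)cc2n1Cc1cn(-c2ccc(Cl)cc2)nn1`, gives 65.1% in this assay.

Compound 1 holds the higher of the two numbers; compound 2 sits lower by a margin beyond the usual scatter. The two compounds differ in more than one place, so the gap between them is not assigned to any single change.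

Compound 3, `Cc1ccc2c(c1)oc(=O)n2Cc1cn(-c2ccc(Cl)cc2)nn1`, is not yet measured in this assay. It differs from compound 1 by chloro in place of fluoro on an aromatic carbon. Among the measured compounds shown here, no measured pair isolates this change, so the size of the step from compound 1 to compound 3 is not read from any measured step. Compound 2, which also carries 4-chlorophenyl, differs from compound 1 in its core as well, so its lower number cannot be laid on the chloro alone. A step within the scatter, leaning slightly downward, is expected: a number 6.6 percentage points lower from compound 1 to compound 3 (within the scatter). The estimate for compound 3 is 74%, expected to fall between 60% and 86%.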

Compound 3, a percentage reported as inhibition, in the whole organism at one dose (the size of the read-out at that dose, not a potency): 76.7%
Estimate against measurement, compound 3: 2.7 percentage points below, within the range that was stated.
By their numbers in this assay, from the lowest: compound 2; then compounds 3 and 1 (each within the scatter of the next).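

In this assay, among the compounds shown here, the pair gives the first isolated reading of the change from 4-fluorophenyl to 4-chlorophenyl: on the core of compound 1, chloro in place of fluoro gives a number 3.9 percentage points lower from compound 1 to compound 3 (within the scatter), so this pair does not separate the two halogens at this position. For the compounds shown here, the reading holds only for this core and for the single dose tested, and it gives no potency for either compound. No measured evidence on hand bears on the reason for this result.

The compounds shown leave open how this position would read with anything other than these two halogens, such as a methoxy group, an amine or a carboxylic acid, and so whether the read-out can be moved beyond the scatter by a change at this place. Going by these compounds alone, they also leave open whether the fluoro and chloro groups would stay within the scatter of each other on a different core, as no second matched pair carrying this change is available.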